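A few compounds are considered here, and "the series" means these few. Any claim that something is new, unique, unknown or untested is made for them only; others in the source may bear on it.

Two compounds of a shared core have been examined in an ADME assay on Vero cells (Chlorocebus sabaeus) for cytotoxicity, read by sulforhodamine B assay, with a stated time of 72 h; on this read-out higher numbers stand for weaker inhibition and lower numbers for stronger inhibition. Compound 1 `CN1Cc2ccc(OCC3CCCCC3)cc2[C@@H](O)C1` carries a cyclohexylmethoxy group and gives 65600 nM in this assay. Compound 2 `CN1Cc2ccc(OCc3ccc(Oc4ccccc4)cc3)cc2[C@@H](O)C1`, with a phenoxybenzyloxy group in the same region, gives 3400 nM. On these two numbers compound 2 stands lowest, and the gap from compound 1 lies well beyond the scatter of repeated measurements, so compound 2 is the more cytotoxic of the pair.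

Compound 3 `CN1Cc2ccc(OCc3ccc(Br)cc3)cc2[C@@H](O)C1` has not yet been measured. It differs from compound 2 in one place: bromo in place of phenoxy on an aromatic carbon. The outer aromatic ring is thus removed and a single bromine atom stands in its place. No step between measured compounds covers such a change, so the expectation rests only on the two numbers shown. Because compound 1, the smaller of the two measured compounds, gives 65600 nM, a move toward a smaller group is expected to raise the number moderately; the step of a 2.9-fold higher number from compound 2 to compound 3 (0.47 log units; beyond the scatter) is expected to lie a little beyond the scatter. Compound 3 is therefore estimated at 10000 nM, within a range from 3500 nM to 30000 nM.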

Compound 3, half-maximal inhibitory concentration: 37000 nM
The estimate for compound 3 lay 3.7-fold (0.57 log units) below the measured number, and the stated range ends below it.
By their numbers in this assay, from the lowest: compound 2; then compounds 3 and 1 (each within the scatter of the next).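

In this assay, bromo in place of phenoxy on an aromatic carbon, para to a large group, gives an 11-fold higher number from compound 2 to compound 3 (1.04 log units; beyond the scatter), a large step that ties the low number of compound 2 to the phenoxy group and shows that the inner aromatic ring with a single bromine atom at this place does not keep that number. The second comparison shows that an aromatic ring in this region is not enough on its own: 4-bromophenyl in place of cyclohexyl gives a 1.8-fold lower number from compound 1 to compound 3 (0.25 log units; within the scatter), which stays within the scatter, so this pair is not told apart in the assay. Nothing measured alongside these numbers accounts for either step.

The compounds shown leave open whether the low number of compound 2 depends on the outer ring itself or on the oxygen that links it, a question that a benzyl group or a directly attached phenyl group in place of phenoxy would address. They also leave open how a chlorine atom, a methoxy group or a morpholine at the same aromatic carbon would compare with bromo and phenoxy.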